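Swapping the amide's ethyl for a furan ring

The source may hold more compounds than are shown below. What is called first, only, known or untested is meant among the compounds shown, and "the series" means these compounds.

Measured compounds and their values:
- compound 1 `CCCCC(=O)Nc1ccc(N2CCN(c3ccc(OC[C@@H]4CO[C@@](Cn5cncn5)(c5ccc(Cl)cc5Cl)O4)cc3)CC2)cc1`: 14100 nM
- compound 2 `CCC(=O)Nc1ccc(N2CCN(c3ccc(OC[C@@H]4CO[C@@](Cn5cncn5)(c5ccc(Cl)cc5Cl)O4)cc3)CC2)cc1`: 5460 nM
- compound 3 `O=C(Nc1ccc(N2CCN(c3ccc(OC[C@@H]4CO[C@@](Cn5cncn5)(c5ccc(Cl)cc5Cl)O4)cc3)CC2)cc1)C(/C=C/Cl)C/C=C/C(F)(F)F`: 9570 nM

All three share one core and differ only in the group attached to the carbonyl carbon of an amide. In a functional assay on HepG2 cells (Homo sapiens) for inhibition, read by MTT assay, with a stated time of 48 h (a higher number here means a weaker inhibitor, a lower number a stronger inhibitor), compound 2 gives 5460 nM. The step of a 2.6-fold lower number from compound 1 to compound 2 (0.41 log units; beyond the scatter) is beyond the scatter, so compound 2 is a clearly stronger inhibitor than compound 1; the step of a 1.8-fold higher number from compound 2 to compound 3 (0.24 log units; within the scatter) is within the scatter, so compound 2 and compound 3 cannot be told apart on these numbers.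

Compound 4 `O=C(Nc1ccc(N2CCN(c3ccc(OC[C@@H]4CO[C@@](Cn5cncn5)(c5ccc(Cl)cc5Cl)O4)cc3)CC2)cc1)c1ccco1` has not yet been measured. It differs from compound 2 by furan-2-yl in place of ethyl on a carbonyl carbon. Among the measured compounds shown here, the steps that bear on this are the other changes at the same carbonyl carbon: a 1.5-fold lower number from compound 1 to compound 3 (0.17 log units; within the scatter) and a 1.8-fold higher number from compound 2 to compound 3 (0.24 log units; within the scatter), both within the scatter, while the chain shortening a 2.6-fold lower number from compound 1 to compound 2 (0.41 log units; beyond the scatter) was modest. Nothing measured here involves an aromatic ring at this position, so the furan change is a step into untested ground, and the expectation is a change of no more than the scatter, with the number most likely staying near that of compound 2.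

For compound 4 in this assay the estimate is therefore 6500 nM, with a range from 2500 nM to 17000 nM, which means an expected step of a 1.2-fold higher number from compound 2 to compound 4 (0.08 log units; within the scatter).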

Compound 4, half-maximal inhibitory concentration: 22300 nM
Compound 4: middle estimate off by 3.4-fold (0.54 log units), on the low side, outside the stated range (above it).
By their numbers in this assay, from the lowest: compounds 2, 3, 1 and 4 (each within the scatter of the next, the first and the last beyond it).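

Among the compounds shown here, the furan-2-yl ring is the first aromatic ring seen on this carbonyl carbon, and in this assay it gives a 4.1-fold higher number from compound 2 to compound 4 (0.61 log units; beyond the scatter) and a 2.3-fold higher number from compound 3 to compound 4 (0.37 log units; beyond the scatter) as well, so compound 4 is a clearly weaker inhibitor than either of those two. The position therefore does not accept every new group equally, even though the large, branched group of compound 3 could not be told apart from the ethyl of compound 2. Compound 4 also shows a 1.6-fold higher number from compound 1 to compound 4 (0.20 log units; within the scatter), which means the furan-2-yl ring and the butyl chain of compound 1 cannot be separated here, although both fall short of the ethyl group in compound 2, and nothing available explains this loss.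

As far as these compounds go, it remains open whether the drop follows from having a ring at all, from its aromatic character or from the ring oxygen, which a phenyl ring, a thiophene ring or a saturated cyclopentyl ring on the same carbonyl carbon could help separate. The compounds shown also leave open whether a methyl group, shorter than ethyl, would continue the gain seen when butyl gives way to ethyl.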